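Swapping hydroxy for fluoro on the aromatic ring

The source may hold more compounds than are shown below. What is called first, only, known or untested is meant among the compounds shown, and "the series" means these compounds.

Of the compounds shown here, two sharing one core have numbers so far in a functional assay on HUVEC cells (Homo sapiens) for cytotoxicity; on this read-out lower numbers stand for an effect already at smaller amounts and higher numbers for an effect only at larger amounts of compound. Compound 1 `COC1=C(C)C(=O)/C(=C(O)/C=C/c2ccccc2OC)C(=O)C1(C)C` gives 1.7 ug/mL, and compound 2 `COC1=C(C)C(=O)/C(=C(O)/C=C/c2ccc(O)cc2)C(=O)C1(C)C` gives 3.8 ug/mL, the higher of the two numbers. Compound 3 `COC1=C(C)C(=O)/C(=C(O)/C=C/c2ccc(F)cc2)C(=O)C1(C)C` is the next to be read. It differs from compound 2 by fluoro in place of hydroxy on an aromatic carbon, para to a large group: fluoro in place of hydroxy on an aromatic carbon.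

Among the measured compounds shown here, only one measured step bears on this change: a 2.2-fold higher number from compound 1 to compound 2 (0.35 log units; beyond the scatter). It is modest and beyond the scatter, but it brings in the hydroxy group while another group leaves, so it is only indirect evidence. For the measured compounds named here, no measured pair compares fluoro with hydroxy directly. Like compound 1 at 1.7 ug/mL, compound 3 has no hydroxy on an aromatic carbon, which gives a weak lean toward a lower number. In this assay, a small shift in that direction is therefore expected, probably not beyond the scatter. The expected step is a 1.5-fold lower number from compound 2 to compound 3 (0.16 log units; within the scatter). The estimated value for compound 3 is 2.6 ug/mL, with an expected range of 1.1 ug/mL to 6 ug/mL.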

Compound 3, concentration for half-maximal effect: 2 ug/mL
Beside the measured number, compound 3's estimate is 1.3-fold (0.11 log units) above it; low and high end bracket the measured number.
By their numbers in this assay, from the lowest: compounds 1, 3 and 2 (each within the scatter of the next, the first and the last beyond it).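

In this assay, among the compounds shown here, the first direct reading of fluoro against hydroxy on this aromatic carbon gives a small step (a 1.9-fold lower number from compound 2 to compound 3 (0.28 log units; within the scatter)), so replacing the hydroxy group, a hydrogen-bond donor and acceptor, with fluoro, which is counted as neither, does not move the number beyond the scatter. Compound 3 also stays close to the 2-methoxyphenyl compound (a 1.2-fold higher number from compound 1 to compound 3 (0.07 log units; within the scatter)), whereas the 4-hydroxyphenyl compound had separated from it beyond the scatter (a 2.2-fold higher number from compound 1 to compound 2 (0.35 log units; beyond the scatter)), so the three compounds span only a narrow range and compound 3 cannot be told apart from either of the other two. No measurement shown here offers an explanation for these small steps.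

Going by these compounds, whether an amine or a carboxylic acid on the same aromatic carbon would keep the number inside this narrow range remains open. The comparisons with compound 1 change both the group and its place on the ring, so the compounds shown do not separate the contribution of each.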